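The source may hold more compounds than are shown below. What is called first, only, known or untested is meant among the compounds shown, and "the series" means these compounds.

Measured so far:
compound 1 `CC(=O)c1cccc(NC(=O)N[C@@H](C)c2ccccc2)c1` – 94%
compound 2 `C[C@H](NC(=O)Nc1cccc(Cl)c1)c1ccccc1` – 103%

Within the data shown here, in an ADME assay on the whole organism with Oryza sativa as the target, tested at 10 uM (on this read-out lower numbers stand for a stronger effect and higher numbers for a weaker effect at the one concentration tested), compound 2 stands highest of the two numbers; the one step measured is a number 9 percentage points higher from compound 1 to compound 2 (within the scatter), so the two values cannot be told apart. Compound 3 `C[C@H](NC(=O)Nc1cccc(Cl)c1Cl)c1ccccc1` differs from compound 2 by chloro in place of hydrogen on an aromatic carbon. Among the measured compounds shown here, that single measured step swapped one group for another and is the only guide; it gives no sign that adding a chloro group moves this read-out beyond the scatter. For the measured compounds named here, no step is therefore expected. Compound 3 is estimated at 100%, between 86% and 112%. The expected step is a number 3 percentage points lower from compound 2 to compound 3 (within the scatter).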

Compound 3, a percentage reported as activity, at one concentration (the size of the read-out at that concentration, not a potency): 101%
Compound 3: middle estimate off by 1 percentage points, on the low side; measured number inside the range.
By their numbers in this assay, from the lowest: compounds 1, 3 and 2 (each within the scatter of the next).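

In this assay, the step of a number 2 percentage points lower from compound 2 to compound 3 (within the scatter) comes from adding a chloro group where a hydrogen stood, ortho to a chloro group, and it stays within the scatter. So a second chloro group can be added at this position of the ring without a measurable shift in the read-out, whereas the earlier step only replaced one group with another. No measurement here bears on the reason for this result. On these data alone, whether an amine or a carboxylic acid at this position would shift the read-out remains open. So does whether this chloro group would behave the same without its chloro neighbour.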